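Methyl Added to a Chain Carbon: Expected Effect on Clearance

A few compounds are considered here, and "the series" means these few. Any claim that something is new, unique, unknown or untested is made for them only; others in the source may bear on it.

Compound 1 `CCc1nc2nc(C)cc(Nc3ccc(Cl)cc3)n2n1`: 63.1 mL.min-1.g-1
Compound 2 `Cc1cc(Nc2ccc(S(F)(F)(F)(F)F)cc2)n2nc(C(C)(F)F)nc2n1`: 8.1 mL.min-1.g-1
Compound 3 `CCC(F)(F)c1nc2nc(C)cc(Nc3ccc(S(F)(F)(F)(F)F)cc3)n2n1`: 6.7 mL.min-1.g-1

In an in vitro ADME assay on microsomes from liver (Mus musculus) for metabolic stability (a lower number here means slower removal, a higher number faster removal of the compound), compound 1 gives the highest number of the three, and its values against compounds 2 and 3 both lie beyond the scatter. The difference between the core of compound 1 and that of compound 2 is not broken down here. Compounds 2 and 3 share a core and differ by methyl in place of hydrogen on a saturated chain carbon, two bonds along the chain from an aromatic carbon and two fluorine atoms; this gave a 1.2-fold lower number from compound 2 to compound 3 (0.08 log units; within the scatter).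

Compound 4 `Cc1cc(Nc2ccc(Cl)cc2)n2nc(C(C)C)nc2n1` differs from compound 1 by methyl in place of hydrogen on a saturated chain carbon bound to an aromatic carbon and a saturated chain carbon. This is the same kind of change as from compound 2 to compound 3, but not the same: there the methyl enters two bonds along the chain from an aromatic carbon and two fluorine atoms, here it enters on a carbon bound to an aromatic carbon and a saturated chain carbon. Resting on a 1.2-fold lower number from compound 2 to compound 3 (0.08 log units; within the scatter), which stayed within the scatter, compound 4 is expected to show a 1.1-fold lower number from compound 1 to compound 4 (0.04 log units; within the scatter). Compound 4 is therefore estimated at 58 mL.min-1.g-1, most likely between 30 mL.min-1.g-1 and 115 mL.min-1.g-1.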

Compound 4, intrinsic clearance in microsomes in the liver assay: 158 mL.min-1.g-1
The estimate for compound 4 lay 2.7-fold (0.44 log units) below the measured number, and the stated range ends below it.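

In the liver assay the methyl in place of hydrogen gave a 2.5-fold higher number from compound 1 to compound 4 (0.40 log units; beyond the scatter), so the change did not carry over unaltered from one core to the other: the same change on two cores in the liver assay, a 1.2-fold lower number (0.08 log units; within the scatter) from compound 2 to compound 3 and a 2.5-fold higher number (0.40 log units; beyond the scatter) from compound 1 to compound 4, 3.0-fold (0.48 log units) apart, beyond the scatter of two such steps. The same step also raised the number in a physicochemical assay for lipophilicity, at pH 7.4 (on this read-out higher numbers stand for higher lipophilicity and lower numbers for lower lipophilicity), where compound 1 gives 2.8 and compound 4 gives 3.2: the measured distribution coefficient of compound 1, 2.8, and of compound 4, 3.2, a number 0.40 log units higher (beyond the scatter). Whether that rise is tied to the faster removal is not shown, and a single pair on each core cannot say which difference between the cores separates the two steps.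

The compounds shown leave open how clearance would read on the core of compound 1 with a longer chain or a cyclopropyl group in place of the isopropyl. They also leave open what an amine on that chain would do.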